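Pyridin-4-yl in Place of Phenyl on a Ring Nitrogen

The compounds below may be only part of what the source reports. "The series", "measured", "known", "first", "only" and "open" are said of these compounds alone.

Of the compounds shown here, two have been measured so far in a functional assay on A-375 cells (Homo sapiens) for antiproliferative activity, read by CCK-8 assay, with a stated time of 72 h; a higher number here means a weaker inhibitor, a lower number a stronger inhibitor. There, compound 1 `Nc1ccccc1NC(=O)c1ccc(CSC(=S)N2CCN(c3ccccc3)CC2)cc1` gives 3670 nM and compound 2 `CCN(Cc1ccncc1)C(=S)SCc1ccc(C(=O)Nc2ccccc2N)cc1` gives 1940 nM. Within the data shown here, compound 1 therefore stands within the usual scatter of compound 2, the only other measured compound, so the two cannot be told apart in this assay. The next compound, compound 3 `Nc1ccccc1NC(=O)c1ccc(CSC(=S)N2CCN(c3ccncc3)CC2)cc1`, keeps the core of compound 1 and has pyridin-4-yl in place of phenyl on an amine nitrogen in a ring. Among the measured compounds shown here, no measured pair isolates this change. For the measured compounds named here, the only guide is compound 2, which also holds a pyridin-4-yl group and gives 1940 nM. The expected change, a 1.4-fold lower number from compound 1 to compound 3 (0.15 log units; within the scatter), is a small estimated move toward a lower number that stays within the scatter. For compound 3 the estimated value is 2600 nM, with an expected range of 1000 nM to 6500 nM.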

Compound 3, half-maximal inhibitory concentration: 1270 nM
Beside the measured number, compound 3's estimate is 2.0-fold (0.31 log units) above it; the measured number falls inside the stated range.
By their numbers in this assay, from the lowest: compounds 3, 2 and 1 (each within the scatter of the next, the first and the last beyond it).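

In this assay, pyridin-4-yl in place of phenyl on the amine nitrogen in the ring gives a 2.9-fold lower number from compound 1 to compound 3 (0.46 log units; beyond the scatter), so this position responds to the change by more than the scatter, which the earlier pair of compounds could not show. The swap keeps the heavy-atom count and the shared core, exchanging one ring carbon for a nitrogen and adding one hydrogen-bond acceptor, while compound 2 differs from both in more than one place and does not bear on this step. No measurement shown here accounts for the size of the step.

From the compounds shown here alone, it remains open whether pyridin-3-yl or pyridin-2-yl on the same nitrogen would give a similar step. Equally open, going by these compounds, is how a phenyl ring carrying a methoxy group or a carboxylic acid would compare with compound 3.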